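The source may report more compounds than this note shows. Statements on the series, on what has been measured and on what is new or still open speak of the compounds shown alone.

Measured so far:
- compound 1, `CCOC(=O)c1csc(-c2csc(-c3csc([C@H](C)NC(=O)OC(C)(C)C)n3)n2)n1`: "active" (no number reported) in a functional assay on HCT-116 cells (Homo sapiens) for inhibition, read by CCK-8 assay, tested at 50 uM (on this read-out higher numbers stand for more inhibition at the one concentration tested (going by the name of the read-out) and lower numbers for less inhibition), reported without a number
- compound 2, `C[C@@H](NC(=O)OC(C)(C)C)c1nc(-c2nc(-c3nc(C(N)=O)cs3)cs2)cs1`: 70%

Among the compounds with values here, compound 2 carries the only number in the set; in this assay compound 2 gives 70%. Within the data shown here, compound 1 stands beside it as a qualitative entry only, so no step between measured compounds can be worked out, and nothing here tells how changes at the stereocentre move the read-out.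

Compound 3, `C[C@H](NC(=O)OC(C)(C)C)c1nc(-c2nc(-c3nc(C(N)=O)cs3)cs2)cs1`, is the compound to be measured. Its relation to compound 2 is the two compounds have the same atoms and bonds and differ only in configuration as drawn: 1 of 1 stereo elements differ; a stereocentre at a saturated chain carbon is drawn R in compound 2 and S in compound 3. Among the measured compounds shown here, no measured pair shows what such a change does in this assay, so the expected step size rests on general experience alone: a change at the single stereocentre can leave the read-out unchanged within the scatter or lower it markedly, and a moderate fall is taken as the middle case. The expected step is a number 20 percentage points lower from compound 2 to compound 3 (beyond the scatter). Compound 3 is therefore estimated at 50% in this assay, with a likely range of 15% to 80%.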

Compound 3, a percentage reported as inhibition, at one concentration (the size of the read-out at that concentration, not a potency): 70%
Compound 3: the middle estimate sits 20 percentage points below what was measured; measured number inside the range.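

In this assay, inverting the stereocentre at the saturated chain carbon gives no change at the digits printed from compound 2 to compound 3 (within the scatter). Within the data shown here, this is the first measured pair, and it shows that, at the one concentration tested, the read-out does not separate the R drawing from the S drawing at this carbon. The comparison concerns configuration alone, with no other structural change to take into account: the fact that compounds 2 and 3 differ only in the configuration as drawn

Going by these compounds, because the read-out is a single-concentration figure and not a potency, it remains open whether compound 2 and compound 3 would also match across a range of concentrations. Also open, on these data alone, is how the read-out responds to changes in the groups themselves, such as a free amine in place of the carbamate on the chain or a carboxylic acid in place of the primary carboxamide, and whether the indifference to configuration at this carbon would persist with either replacement.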